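The source may report more compounds than this note shows. Statements on the series, on what has been measured and on what is new or still open speak of the compounds shown alone.

Measured in a functional assay on L5178Y cells (Mus musculus) for inhibition, read by MTT assay, with a stated time of 24 h; a lower number here means a stronger inhibitor, a higher number a weaker inhibitor:
- Compound 1 `O=C(N/N=C1\C[C@@H](c2ccc(O)cc2)Oc2cc(O)cc(O)c21)c1ccco1`: >= 11300 nM, a limit
- Compound 2 `O=C(Cc1c[nH]c2ccccc12)N/N=C1\C[C@@H](c2ccc(O)cc2)Oc2cc(O)cc(O)c21`: >= 11300 nM, a limit

Compound 2 therefore has no numerical value on this read-out, only a limit. Compound 3 `COc1cc(O)c2c(c1)O[C@H](c1ccc(O)cc1)C/C2=N\NC(=O)Cc1c[nH]c2ccccc12` differs from it in one place: methyl in place of hydrogen on an oxygen on an aromatic ring, a change from hydroxy to methoxy. Among the compounds with values here, the only measured step, a step that the two limits leave unreadable from compound 1 to compound 2, has (1H-indol-3-yl)methyl in place of furan-2-yl on a carbonyl carbon. Within the data shown here, it gives no readable size, and no measured step covers hydroxy to methoxy. Compound 1 and compound 2 both rest at the limit of >= 11300 nM in this assay, at which 2 of the 2 values shown sit, so compound 3 is expected to stay close to that limit in this assay, with no firm direction. The expected change is a step that the limit leaves unreadable from compound 2 to compound 3. For compound 3 the estimated value is 15000 nM. The expected range for compound 3 runs from 6000 nM to 40000 nM.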

Compound 3, half-maximal inhibitory concentration: >= 11300 nM
Compound 3 gave a limit, no number (the forecaster's own chance of this, stated with the estimate: 65%); the middle value lies beyond the limit too.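

The step from compound 2 to compound 3, hydroxy to methoxy, cannot be read, as both compounds give only a limit. Compound 1 shares that limit with them: the limit of >= 11300 nM in this assay, at which 3 of the 3 values shown sit. The compounds shown leave open what numerical value any of the three would have and whether either change shifts it.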